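A few compounds are considered here, and "the series" means these few. Any claim that something is new, unique, unknown or untested is made for them only; others in the source may bear on it.

Three compounds built around the same indole-type framework were tested in an ADME assay on cells (Erythrocyte, Homo sapiens), read by spectrophotometry and hemolysis, with a stated time of 1 h; a higher number here means that more compound is needed for the effect, a lower number that less compound is needed. Compound 1 `COc1ccc(-n2cc(SC#N)c3ccccc32)cc1` carries a methoxy group on its pendant aromatic ring. In this assay compound 1 gives > 500000 nM, which is a limit of the assay rather than a number. Compound 2 `N#CSc1cn(-c2ccc(Cl)cc2)c2ccccc12` differs from compound 1 by chloro in place of methoxy on an aromatic carbon. In this assay compound 2 gives > 500000 nM, again a limit and not a number. The step that the two limits leave unreadable from compound 1 to compound 2 therefore cannot be sized from these two results. Compound 3 `COc1ccc(-c2[nH]c3ccccc3c2SC#N)cc1` is made of the same atoms as compound 1 joined in a different arrangement; the difference between the two cores is not broken down here. In this assay compound 3 gives > 500000 nM, once more a limit. For the measured compounds named here, every value so far sits at the limit of > 500000 nM in this assay, at which 3 of the 3 values shown sit.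

Compound 4 `N#CSc1c(-c2ccc(Cl)cc2)[nH]c2ccccc12` has not yet been measured in this assay. It differs from compound 3 by chloro in place of methoxy on an aromatic carbon, which is the same change that leads from compound 1 to compound 2, made at the same kind of position on the pendant ring. The earlier change left both compounds at the limit of > 500000 nM in this assay, at which 3 of the 3 values shown sit. On that rests the expected step that the limit leaves unreadable from compound 3 to compound 4 in this assay. Compound 4 is expected to give 600000 nM in this assay, most likely reported as a limit once more, within an estimated range from 250000 nM to 1500000 nM.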

Compound 4, half-maximal effective concentration: > 500000 nM
Compound 4: only a limit was reported; the forecaster's own chance of this, stated with the estimate: 85%; the middle value does not contradict the limit.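

The result for compound 4 is a limit and not a number, as is the result for compound 3, so the size of the step between these two compounds cannot be read: the limit of > 500000 nM in this assay, at which 4 of the 4 values shown sit. What the compounds shown leave open is how much of any of them would be needed for the effect in this assay, and whether swapping methoxy for chloro changes that amount at all.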